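Swapping a Bromothiophene for a Thiazole: Cytotoxicity Outlook

The source may report more compounds than this note shows. Statements on the series, on what has been measured and on what is new or still open speak of the compounds shown alone.

Compound 1 `C[C@H]1[C@H](NCc2cc(Br)cs2)C[C@H]2C[C@@H]1C2(C)C` was tested in an ADME assay on MDCK cells (Canis lupus familiaris) for cytotoxicity, read by microscopy, with a stated time of 48 h (a lower number here means that less compound is tolerated, a higher number that more compound is tolerated), where compound 1 gives 6250 nM. Among the two numbers measured, compound 1 sits at the higher one; the nearest is compound 2 `C[C@H]1[C@H](NCc2cc(-c3ccccc3)cs2)C[C@H]2C[C@@H]1C2(C)C`, which in this assay gives 5000 nM, and the step of a 1.3-fold lower number from compound 1 to compound 2 (0.10 log units; within the scatter) lies within the scatter. Compound 3 `C[C@H]1[C@H](NCc2nccs2)C[C@H]2C[C@@H]1C2(C)C` has not yet been measured in this assay. It differs from compound 1 by 1,3-thiazol-2-yl in place of 4-bromothiophen-2-yl on a saturated chain carbon bound to an amine nitrogen. Among the compounds with values here, the only measured step, the one from compound 1 to compound 2, changed a different part of the ring and stayed within the scatter, so it offers limited guidance here. With no measured change having moved the number beyond the scatter, compound 3 is expected to show a step of no change at the digits printed from compound 1 to compound 3 (within the scatter) that stays within that scatter. Compound 3 is therefore estimated at 6250 nM, with a range from 3000 nM to 12500 nM.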

Compound 3, minimum cytotoxic concentration: > 100000 nM
Compound 3 gave a limit, no number; the forecaster's own chance of this, stated with the estimate: 10%; middle value at least 16-fold (1.20 log units) from the limit.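

In this assay, putting 1,3-thiazol-2-yl in place of 4-bromothiophen-2-yl on a saturated chain carbon bound to an amine nitrogen gives an at least 16-fold higher number from compound 1 to compound 3 (1.20 log units; beyond the scatter). The other step shown, a 1.3-fold lower number from compound 1 to compound 2 (0.10 log units; within the scatter), stayed within the scatter, so this is the first change here to move the number clearly, and it shows that replacing the whole aromatic ring can matter far more than replacing the bromo group on it. The result for compound 3 is a limit, not a number: the limit of > 100000 nM in this assay, at which 1 of the 3 values shown sits.

In this single change the bromine leaves and a ring nitrogen enters together, so the compounds shown cannot tell which of the two goes with the higher number. An unsubstituted thiophen-2-yl group or a thiazole ring carrying a bromo group would pull these two changes apart.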